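The compounds below may be only part of what the source reports. "The series", "measured", "known", "first", "only" and "open" are said of these compounds alone.

Measured so far in an in vitro functional assay on CHO/Galpha16 cells for antagonist activity at C-C chemokine receptor type 8 (Homo sapiens), read by FLIPR; on this read-out higher numbers stand for weaker inhibition and lower numbers for stronger inhibition:
compound 1, `CCCC(=O)N1CCC(NS(=O)(=O)c2ccc(NC(=O)c3ccc(F)cc3)c3ccccc23)CC1`, gives 59.5 nM
compound 2, `CCCC(=O)N1CCC(NS(=O)(=O)c2ccc(NC(=O)c3ccc(C(C)(C)C)cc3)c3ccccc23)CC1`, gives 6.9 nM

Among the compounds with values here, compound 2 stands with the lowest number of the two; its nearest neighbour is compound 1, and the single step measured, an 8.6-fold lower number from compound 1 to compound 2 (0.94 log units; beyond the scatter), is the exchange of tert-butyl in place of fluoro on an aromatic carbon.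

Compound 3, `CCCC(=O)N1CCC(NS(=O)(=O)c2ccc(NC(=O)c3nccn3C)c3ccccc23)CC1`, has not yet been measured in this assay. Its change from compound 2 is 1-methyl-1H-imidazol-2-yl in place of 4-(tert-butyl)phenyl on a carbonyl carbon. Within the data shown here, the entering group carries neither the tert-butyl of compound 2 nor the fluoro of compound 1, and it is a five-membered aromatic ring with two hetero atoms where a six-membered ring of carbon only stood; no measured step covers such a swap directly. Among the measured compounds shown here, the only step that bears on it is an 8.6-fold lower number from compound 1 to compound 2 (0.94 log units; beyond the scatter), which shows that the group on that aromatic carbon moves the number well beyond the scatter. Removing the tert-butyl altogether is expected to undo much of that gain, so compound 3 is expected to give a higher number than compound 2, the estimated step being a 12-fold higher number from compound 2 to compound 3 (1.06 log units; beyond the scatter). Compound 3 is estimated at 80 nM, with a range from 15 nM to 400 nM.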

Compound 3, half-maximal inhibitory concentration: 20.4 nM
The estimate for compound 3 lay 3.9-fold (0.59 log units) above the measured number, and the stated range covers the measured number.
By their numbers in this assay, from the lowest: compound 2; then compound 3; then compound 1.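

In this assay, the 4-(tert-butyl)phenyl group on the carbonyl carbon can be replaced by the smaller 1-methyl-1H-imidazol-2-yl at a limited cost, with a 3.0-fold higher number from compound 2 to compound 3 (0.47 log units; beyond the scatter), and this step is smaller than the one that separates the two phenyl amides. Set against 4-fluorophenyl, the same five-membered ring gives a 2.9-fold lower number from compound 1 to compound 3 (0.46 log units; beyond the scatter), so a tert-butyl group is not needed for a number lower than that of compound 1, and a six-membered aromatic ring of carbon only is not needed either. Among these three compounds, ring type alone does not set the order, since the imidazole amide falls between the two phenyl amides, and no measurement at hand accounts for that order.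

Still open, going by these compounds, is how much the ring nitrogens and the methyl group each contribute, which a pyridine, an unmethylated imidazole or a longer alkyl chain on the imidazole nitrogen would begin to separate. All three compounds share the rest of the core, so they say nothing about whether this order holds with a different acyl group on the piperidine nitrogen, such as acetyl or benzoyl.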